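Trifluoromethyl on the aryl amine of a fused core

This account rests on a few compounds, and the source may have more. Where it says the series, first, only, none or still open, it means among the compounds named here.

Measured so far:
compound 1, `Cc1ccc(NC2=CC(=O)c3nc4n(c3C2=O)[C@H]2OC[C@@H](O)[C@H]2OC4)cc1`, 1420 nM in a functional assay on MGC-803 cells (Homo sapiens) for inhibition, read by sulforhodamine B assay; a higher number here means a weaker inhibitor, a lower number a stronger inhibitor
compound 2, `Cc1ccc(NC2=CC(=O)c3nc4n(c3C2=O)[C@H]2OC[C@@H](O)[C@H]2OC4)cc1C`, 860 nM
compound 3, `O=C1C=C(Nc2ccccc2)C(=O)c2c1nc1n2[C@H]2OC[C@@H](O)[C@H]2OC1`, 1730 nM

Compound 3 gives the highest of the three numbers, yet its steps to compound 1 and compound 2 both sit within the scatter: a 1.2-fold higher number from compound 1 to compound 3 (0.09 log units; within the scatter) and a 2.0-fold higher number from compound 2 to compound 3 (0.30 log units; within the scatter). The next compound, compound 4, `O=C1C=C(Nc2ccc(C(F)(F)F)cc2)C(=O)c2c1nc1n2[C@H]2OC[C@@H](O)[C@H]2OC1`, differs from compound 3 by trifluoromethyl in place of hydrogen on an aromatic carbon. Among the compounds with values here, the only guidance comes from the methyl steps. One is a 1.7-fold lower number from compound 1 to compound 2 (0.22 log units; within the scatter). The other is a 1.2-fold higher number from compound 1 to compound 3 (0.09 log units; within the scatter). Both stayed within the scatter, so a substituent on that ring has so far moved little. Compound 4 is therefore expected to land near compound 3, with a step of a 1.3-fold lower number from compound 3 to compound 4 (0.12 log units; within the scatter), and is estimated at 1300 nM, between 500 nM and 3500 nM.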

Compound 4, half-maximal inhibitory concentration: 2820 nM
Compound 4: middle estimate off by 2.2-fold (0.34 log units), on the low side, and the stated range covers the measured number.
By their numbers in this assay, from the lowest: compounds 2, 1, 3 and 4 (each within the scatter of the next, the first and the last beyond it).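

In this assay, trifluoromethyl on this ring, para to a large group, stays within the scatter of both hydrogen (a 1.6-fold higher number from compound 3 to compound 4 (0.21 log units; within the scatter)) and methyl (a 2.0-fold higher number from compound 1 to compound 4 (0.30 log units; within the scatter)). Only the comparison with the 3,4-dimethylphenyl group gives a step beyond the scatter, and a modest one (a 3.3-fold higher number from compound 2 to compound 4 (0.52 log units; beyond the scatter)); it is the first such step among these compounds. Nothing shown accounts for these numbers. The compounds leave open whether an amine, a carboxylic acid or a methoxy group in that place would shift the number further. They also leave open whether a substituent elsewhere on the aryl ring would do so.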